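The compounds below may be only part of what the source reports. "The series", "measured", "known", "first", "only" and "open" are said of these compounds alone.

Compound 1 `CC(C)=CCC1=C(O)C(C(=O)C(C)C)=C(O)[C@](O)(CC=C(C)C)C1=O`: 2.92
Compound 2 `CC(C)=CCC1=C(O)C(C(=O)CC(C)C)=C(O)[C@](O)(CC=C(C)C)C1=O`: 3.01

For the measured compounds named here, in a physicochemical assay for lipophilicity, measured as octanol-water partition (on this read-out lower numbers stand for lower lipophilicity and higher numbers for higher lipophilicity), compound 2 gives 3.01, and the only measured step, a number 0.09 log units higher from compound 1 to compound 2 (within the scatter), lies within the scatter, so the two numbers are not separated. Compound 3 `CC(C)=CCC1=C(O)C(C(=O)C(C)C(C)C)=C(O)[C@](O)(CC=C(C)C)C1=O` differs from compound 2 by methyl in place of hydrogen on a saturated chain carbon bound to a carbonyl carbon and a saturated chain carbon. Going by the values given here, that single step is the only one bearing on this change, and it was small. The added methyl is therefore expected to raise the value in this assay only modestly, an estimated step of a number 0.24 log units higher from compound 2 to compound 3 (within the scatter). Compound 3 is estimated at 3.25, with a range from 2.95 to 3.6.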

Compound 3, partition coefficient: 3
Compound 3: the middle estimate sits 0.25 log units above what was measured; low and high end bracket the measured number.
By their numbers in this assay, from the lowest: compounds 1, 3 and 2 (each within the scatter of the next).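

In this assay, methyl in place of hydrogen on a saturated chain carbon bound to a carbonyl carbon and a saturated chain carbon gives a number 0.01 log units lower from compound 2 to compound 3 (within the scatter), so this added carbon produces no resolved difference. Isopropyl in place of methyl on that same carbon gives a number 0.08 log units higher from compound 1 to compound 3 (within the scatter), which leaves all three side chains on the shared core unseparated by this read-out. No independent measurement is available to explain this result. On these data alone, whether a longer chain or an amine in that side chain would give a number beyond the scatter remains open.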